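Bromo to chloro: from compound 2 to compound 4

The compounds below may be only part of what the source reports. "The series", "measured", "known", "first", "only" and "open" are said of these compounds alone.

Values measured in a functional assay on HepG2 cells (Homo sapiens) for antiproliferative activity, read by MTT assay, with a stated time of 48 h (on this read-out higher numbers stand for weaker inhibition and lower numbers for stronger inhibition), are these:
compound 1 `CC(=O)N1N=C(c2ccc3ccccc3c2)OC1c1ccccc1` gives 2.11 ug/mL
compound 2 `CC(=O)N1N=C(c2ccc3ccccc3c2)OC1c1ccccc1Br` gives 3.98 ug/mL
compound 3 `CC(=O)N1N=C(c2ccc3ccccc3c2)OC1c1ccc(Br)cc1` gives 2.08 ug/mL

Compound 2, at 3.98 ug/mL, stands within the scatter of both other compounds in this assay. The series offers a 1.9-fold higher number from compound 1 to compound 2 (0.28 log units; within the scatter) and a 1.9-fold lower number from compound 2 to compound 3 (0.28 log units; within the scatter), and neither separates compound 2 from its neighbours.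

The compound still to be measured is compound 4 `CC(=O)N1N=C(c2ccc3ccccc3c2)OC1c1ccccc1Cl`. It differs from compound 2 by chloro in place of bromo on an aromatic carbon, which is chloro in place of bromo on an aromatic carbon, ortho to a large group. Among the measured compounds shown here, no measured step makes this exchange. The nearest evidence is the step at the same place, a 1.9-fold higher number from compound 1 to compound 2 (0.28 log units; within the scatter), where bromo replaces hydrogen. The same replacement in the 4-bromophenyl compound gives a 1.0-fold lower number from compound 1 to compound 3 (0.01 log units; within the scatter). Both steps stay within the scatter, so a step beyond the scatter is not expected when chloro replaces bromo, and no firm direction can be expected either. The expected step is small, a 1.2-fold lower number from compound 2 to compound 4 (0.09 log units; within the scatter), and stays within the scatter. For compound 4 the estimated value is 3.2 ug/mL, with an expected range from 1.7 ug/mL to 6 ug/mL.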

Compound 4, half-maximal inhibitory concentration: 4.32 ug/mL
Compound 4: middle estimate off by 1.4-fold (0.13 log units), on the low side, within the range that was stated.
By their numbers in this assay, from the lowest: compounds 3, 1, 2 and 4 (each within the scatter of the next, the first and the last beyond it).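

In this assay, the exchange of 2-bromophenyl for 2-chlorophenyl on the saturated ring carbon gives a 1.1-fold higher number from compound 2 to compound 4 (0.04 log units; within the scatter) and so does not separate the two halogens at this place on the aromatic ring. Among the compounds shown here, what compound 4 adds is the first step at this position to pass the scatter: a 2.0-fold higher number from compound 1 to compound 4 (0.31 log units; beyond the scatter) is modest, whereas the bromo step to compound 2 stayed inside it, although compound 2 and compound 4 themselves cannot be told apart. The comparison with the 4-bromophenyl compound also passes the scatter, with a 2.1-fold higher number from compound 3 to compound 4 (0.32 log units; beyond the scatter) as a modest step, but compound 2 goes against any general reading of a halogen at this place, and no measurement at hand offers an explanation for these differences.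

The compounds shown leave open whether a group other than a halogen at this place, such as an amine or a carboxylic acid, would move the number further in either direction. They also leave open whether a 4-chlorophenyl group would stay within the scatter of the 4-bromophenyl compound.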